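Dibutylcarbamate variant of a bis-trimethoxybenzoyl piperazine carbamate

The source may report more compounds than this note shows. Statements on the series, on what has been measured and on what is new or still open speak of the compounds shown alone.

Two measured compounds share a core that carries two trimethoxybenzoyl groups and a carbamate side chain. In a functional assay (Oryctolagus cuniculus) for inhibition of platelet-activating factor receptor (Cavia porcellus) (a higher number here means a weaker inhibitor, a lower number a stronger inhibitor), compound 1 `COc1cc(C(=O)N2CCN(C(=O)c3cc(OC)c(OC)c(OC)c3)C(COC(=O)NC(C)C(C)(C)C)C2)cc(OC)c1OC` gives 170 nM, whereas compound 2 `CCC(C)CNC(=O)OCC1CN(C(=O)c2cc(OC)c(OC)c(OC)c2)CCN1C(=O)c1cc(OC)c(OC)c(OC)c1` gives 470 nM, the highest of the two numbers; the step of a 2.8-fold higher number from compound 1 to compound 2 (0.44 log units; beyond the scatter) shows that the alkyl group on the carbamate nitrogen matters modestly. Compound 3 `CCCCN(CCCC)C(=O)OCC1CN(C(=O)c2cc(OC)c(OC)c(OC)c2)CCN1C(=O)c1cc(OC)c(OC)c(OC)c1` differs from compound 2 by dibutylamino in place of (2-methylbutyl)amino on a carbonyl carbon, so the carbamate nitrogen no longer carries a hydrogen. Within the data shown here, no measured step bears directly on removing that hydrogen; only the step from compound 1 to compound 2, which alters the alkyl group, is at hand, and it was modest. A step of similar modest size, most likely towards a higher number, is therefore expected, a 1.5-fold higher number from compound 2 to compound 3 (0.17 log units; within the scatter). Compound 3 is estimated at 700 nM, within a range from 180 nM to 2800 nM.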

Compound 3, half-maximal inhibitory concentration: 1250 nM
Beside the measured number, compound 3's estimate is 1.8-fold (0.25 log units) below it; measured number inside the range.
By their numbers in this assay, from the lowest: compound 1; then compound 2; then compound 3.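

In this assay, among these compounds, the change to dibutylamino gives a 2.7-fold higher number from compound 2 to compound 3 (0.42 log units; beyond the scatter), the first evidence on a carbamate nitrogen that no longer carries a hydrogen. Here the hydrogen-bond donor is lost while the group grows, and the number rises again. Taken across the series, the change gives a 7.4-fold higher number from compound 1 to compound 3 (0.87 log units; beyond the scatter), so the group on this carbonyl carbon spans a wider range than the first pair showed, though each step remains modest. No available evidence accounts for this rise, and these compounds cannot separate the lost hydrogen from the change in chain.

Dimethylamino, which also lacks that hydrogen but has shorter chains, could separate the two, while octylamino could do the same from the other side by keeping the hydrogen on a longer chain. From the compounds shown here alone, how either group would fare in this assay remains open.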